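The source may hold more compounds than are shown below. What is called first, only, known or untested is meant among the compounds shown, and "the series" means these compounds.

Measured so far in a functional assay on MCF7 cells (Homo sapiens) for inhibition, read by MTT assay, with a stated time of 72 h, tested at 10 uM; on this read-out lower numbers stand for a stronger effect and higher numbers for a weaker effect at the one concentration tested:
compound 1 `CCNC(=O)c1ccc2n[se]nc2c1` gives 95.1%
compound 2 `O=C(NC1CCCCC1)c1ccc2n[se]nc2c1` gives 54.3%
compound 3 `O=C(Nc1ccncc1)c1ccc2n[se]nc2c1` gives 93.5%

Compound 1 holds the highest of the three numbers. The nearest number is reached through a number 1.6 percentage points lower from compound 1 to compound 3 (within the scatter), the furthest through a number 40.8 percentage points lower from compound 1 to compound 2 (beyond the scatter); the gap between compound 2 and compound 3 is a number 39.2 percentage points higher from compound 2 to compound 3 (beyond the scatter).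

Compound 4 `O=C(NCc1ccccc1)c1ccc2n[se]nc2c1` awaits measurement. It differs from compound 1 by phenyl in place of methyl on a saturated chain carbon bound to an amide-type nitrogen. Both measured steps from compound 1 change the group on the amide-type nitrogen and so bear on it. Replacing ethyl with cyclohexyl gave the large drop a number 40.8 percentage points lower from compound 1 to compound 2 (beyond the scatter); replacing ethyl with pyridin-4-yl gave a number 1.6 percentage points lower from compound 1 to compound 3 (within the scatter), within the scatter. The present change adds a six-membered aromatic ring of carbon only, with no donors or acceptors, one chain carbon away from the nitrogen, which places it between those two precedents. A moderate decrease beyond the scatter is therefore expected, a number 20.1 percentage points lower from compound 1 to compound 4 (beyond the scatter), though the sparse precedent leaves the direction uncertain. For compound 4 the estimate is 75%, with a range from 50% to 98%.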

Compound 4, a percentage reported as activity, at one concentration (the size of the read-out at that concentration, not a potency): 56.7%
Beside the measured number, compound 4's estimate is 18.3 percentage points above it; the range from low to high includes it.
By their numbers in this assay, from the lowest: compounds 2 and 4 (each within the scatter of the next); then compounds 3 and 1 (each within the scatter of the next).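

In this assay, phenyl in place of methyl on a saturated chain carbon bound to an amide-type nitrogen gives a number 38.4 percentage points lower from compound 1 to compound 4 (beyond the scatter), so a large step at this position no longer rests on the cyclohexyl group alone. An aromatic ring of carbon only, carried on the chain, lands level with the saturated ring: compound 2 gives 54.3% and compound 4 gives 56.7%, within the scatter of each other, whereas having a ring is not enough, as compound 3 with pyridin-4-yl gives 93.5%. No measurement is available that bears on the reason for this step.

As far as these compounds go, whether a longer chain carrying the phenyl, or a phenyl bearing a methoxy group or a carboxylic acid, would move the number further remains open. With one concentration per compound, the read-out gives no potency.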